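Aryl swap on the saturated ring carbon of the series

This account rests on a few compounds, and the source may have more. Where it says the series, first, only, none or still open, it means among the compounds named here.

Compound 1 `COc1ccc(OC)c(C2OC(c3cc(OC)c(OC)c(OC)c3)=NN2C(C)=O)c1` is the reference in a functional assay on BGC-823 cells (Homo sapiens) for antiproliferative activity, read by MTT assay, tested at 5 uM (on this read-out lower numbers stand for a weaker effect and higher numbers for a stronger effect at the one concentration tested), where compound 1 gives 18.2%. Compound 2 `COc1cc(C2=NN(C(C)=O)C(c3ccc(Cl)c([N+](=O)[O-])c3)O2)cc(OC)c1OC` carries a 4-chloro-3-nitrophenyl on a saturated ring carbon in place of the 2,5-dimethoxyphenyl of compound 1, and in this assay compound 2 gives 0%. Going by the values given here, the only measured step is a number 18.2 percentage points lower from compound 1 to compound 2 (beyond the scatter), a drop beyond the scatter. Among the compounds with values here, on the numbers available compound 2 stands lowest of the two, with compound 1 as its only neighbour.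

Compound 3 `COc1cc(C2=NN(C(C)=O)C(c3cccc(C(F)(F)F)c3)O2)cc(OC)c1OC` differs from compound 2 as follows: 3-(trifluoromethyl)phenyl in place of 4-chloro-3-nitrophenyl on a saturated ring carbon. Within the data shown here, the one measured step bears on it only indirectly, as it shows that the group on this saturated ring carbon moves the read-out by a modest amount. Among the measured compounds shown here, no step with a 3-(trifluoromethyl)phenyl exists here, so the direction is open. The expected outcome is a small rise or none beyond the scatter, that is a number 8 percentage points higher from compound 2 to compound 3 (within the scatter). Compound 3 is estimated at 8%, within 0% to 25%.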

Compound 3, a percentage reported as inhibition, at one concentration (the size of the read-out at that concentration, not a potency): 41.1%
The estimate for compound 3 lay 33.1 percentage points below the measured number; measured number outside the range, above it.
By their numbers in this assay, from the lowest: compound 2; then compound 1; then compound 3.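

In this assay, the group on the saturated ring carbon proves able to raise the read-out as well as lower it: with 3-(trifluoromethyl)phenyl in place of 4-chloro-3-nitrophenyl, the result is a number 41.1 percentage points higher from compound 2 to compound 3 (beyond the scatter), even though the two groups have the same heavy-atom count and each holds one six-membered aromatic ring of carbon only. Against the reference, the same group gives a number 22.9 percentage points higher from compound 1 to compound 3 (beyond the scatter), so 3-(trifluoromethyl)phenyl also stands above 2,5-dimethoxyphenyl at this position, and the three aryl groups separate beyond the scatter. Nothing available on these compounds accounts for the size or direction of these steps.

The compounds shown leave open whether the rise belongs to the trifluoromethyl group itself or to where it sits on the phenyl ring, as no pair here separates these two. Also open, on these data alone, is how an amine or a carboxylic acid on this phenyl ring, or a longer chain in place of the acetyl group, would shift the read-out at the one concentration tested.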